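Lengthening the Hydroxamate Chain by One Carbon

A few compounds are considered here, and "the series" means these few. Any claim that something is new, unique, unknown or untested is made for them only; others in the source may bear on it.

Compound 2 `Nc1nc2cc(-c3nn(CCCCCC(=O)NO)c4ncnc(N)c34)ccc2o1` is measured in a functional assay on HepG2 cells (Homo sapiens) for inhibition, read by MTT assay, with a stated time of 72 h (on this read-out higher numbers stand for weaker inhibition and lower numbers for stronger inhibition), at 1990 nM. For the measured compounds named here, compound 3 `Nc1nc2cc(-c3nn(CCCCCCCCC(=O)NO)c4ncnc(N)c34)ccc2o1` gives 2610 nM in this assay, so that a 1.3-fold higher number from compound 2 to compound 3 (0.12 log units; within the scatter) separates the two, and compound 2 holds one of only two numbers recorded. Compound 1 `Nc1ncnc2c1c(-c1cnc3[nH]ccc3c1)nn2CCCC(=O)NO` reaches only a limit in this assay, > 50000 nM. Compound 4 `Nc1nc2cc(-c3nn(CCCCCCC(=O)NO)c4ncnc(N)c34)ccc2o1` is not yet measured; it differs from compound 2 in one place: (hydroxycarbamoyl)methyl in place of hydroxycarbamoyl on a saturated chain carbon, five bonds along the chain from an aromatic nitrogen. Going by the values given here, the single measured step that bears on this change, the longer extension from compound 2 to compound 3, stayed within the scatter, so no step beyond the scatter is expected for compound 4 in this assay. Compound 4 is therefore estimated at 2200 nM, between 1000 nM and 5000 nM, which is expected to mean a 1.1-fold higher number from compound 2 to compound 4 (0.04 log units; within the scatter).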

Compound 4, half-maximal inhibitory concentration: 1610 nM
Estimate against measurement, compound 4: 1.4-fold (0.14 log units) above; the range from low to high includes it.
By their numbers in this assay, from the lowest: compounds 4, 2 and 3 (each within the scatter of the next). At a limit, above all of these: compound 1.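

In this assay, (hydroxycarbamoyl)methyl in place of hydroxycarbamoyl gives a 1.2-fold lower number from compound 2 to compound 4 (0.09 log units; within the scatter) and so adds no step beyond the scatter at this position. The change to hydroxycarbamoyl in place of 2-(hydroxycarbamoyl)ethyl gives a 1.6-fold lower number from compound 3 to compound 4 (0.21 log units; within the scatter) and also stays within it, so the three chain lengths measured on the shared core show no trend. Nothing measured here accounts for this flat response.

On these data alone, it remains open whether a chain shorter than that of compound 2 or longer than that of compound 3 would move the number beyond the scatter. As far as these compounds go, a carboxylic acid at the chain end in place of the hydroxycarbamoyl group also remains open.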